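The compounds below may be only part of what the source reports. "The series", "measured", "known", "first", "only" and "open" are said of these compounds alone.

Measured compounds:
- compound 1, `CC1CCN(c2c(S(=O)(=O)c3ccc(F)cc3)cnc3ccc(Cl)cc23)CC1`, 89% in an assay on isolated protein for displacement of a labelled ligand from metabotropic glutamate receptor 5 (Homo sapiens), with a stated time of 60 min, tested at 1 uM; a higher number here means more inhibition at the concentration tested (going by the name of the read-out), a lower number less inhibition
- compound 2, `Cc1ccc2ncc(S(=O)(=O)c3cccc(C#N)c3)c(N3CCC(C)CC3)c2c1`, 52%
- compound 3, `COc1ccc2ncc(S(=O)(=O)c3cccc(C#N)c3)c(N3CCC(C)CC3)c2c1`, 90%

Compound 2 stands lowest of the three numbers in this assay: compound 1 lies beyond the scatter above it, and compound 3 lies beyond the scatter above it as well. Among the compounds with values here, the one single-point step among the measured compounds is a number 38 percentage points higher from compound 2 to compound 3 (beyond the scatter), a change at the methyl on the core and not at the sulfonyl group.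

Compound 4, `Cc1ccc(S(=O)(=O)c2cnc3ccc(C)cc3c2N2CCC(C)CC2)cc1`, has not yet been measured. It differs from compound 2 by 4-methylphenyl in place of 3-cyanophenyl on a sulfonyl sulfur. Within the data shown here, no measured step touches this position, so the only step on hand, which concerns the methoxy for methyl change, does not bear on it. With nothing to indicate a direction, no step beyond the scatter is expected, and the estimate for compound 4 carries a wide range: 55%, between 25% and 85%, which means an expected step of a number 3 percentage points higher from compound 2 to compound 4 (within the scatter).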

Compound 4, a percentage reported as inhibition, at one concentration (the size of the read-out at that concentration, not a potency): 82%
Beside the measured number, compound 4's estimate is 27 percentage points below it, and the stated range covers the measured number.
By their numbers in this assay, from the lowest: compound 2; then compounds 4, 1 and 3 (each within the scatter of the next).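

The sulfonyl sulfur's aryl group turns out to be a second place that moves the number in this assay: with the methyl on the core kept, 4-methylphenyl in place of 3-cyanophenyl gives a number 30 percentage points higher from compound 2 to compound 4 (beyond the scatter), so the low value of compound 2 does not depend on the core alone. Because the names of the two groups differ in both the substituent and its ring position, this single step does not show which of the two accounts for the rise. Nothing available explains the result.

Still open, as far as these compounds go, is how a plain phenyl or a 3-methylphenyl on the sulfonyl sulfur would compare, which would separate the nitrile from its ring position. Also open, from the compounds shown here alone, is whether 4-methylphenyl and a methoxy on the core would add together in one compound.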